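Replacing one fluorinated urea ring with another

A few compounds are considered here, and "the series" means these few. Any claim that something is new, unique, unknown or untested is made for them only; others in the source may bear on it.

Measured so far in an assay on isolated protein for inhibition of serine/threonine-protein kinase 10 (Homo sapiens), read by thermal shift assay, tested at 10 uM; on this read-out higher numbers stand for stronger stabilisation of the target against heat and lower numbers for weaker stabilisation of the target:
compound 1 `CC(C)(C)c1cc(NC(=O)Nc2cc(C(F)(F)F)cc(C(F)(F)F)c2)n(-c2ccccc2)n1` gives -0.5 degrees C
compound 2 `Cc1ccc(F)cc1NC(=O)Nc1cc(C(C)(C)C)nn1-c1ccccc1` gives 4.1 degrees C
compound 3 `CC(C)(C)c1cc(NC(=O)Nc2cc(C(F)(F)F)cc(C(F)(F)F)c2)n(-c2ccc(Br)cc2)n1` gives -0.3 degrees C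

Compound 2 stands highest of the three, beyond the scatter above both compound 1 and compound 3. Compound 4 `CC(C)(C)c1cc(NC(=O)Nc2cc(F)cc(F)c2)n(-c2ccccc2)n1` is not yet measured; it differs from compound 2 by 3,5-difluorophenyl in place of 5-fluoro-2-methylphenyl on an amide-type nitrogen. Going by the values given here, the only measured step, a number 0.20 degrees C higher from compound 1 to compound 3 (within the scatter), changes the ring on the core nitrogen, not the ring on the urea, and lies within the scatter, so it says nothing about this change. Among the compounds with values here, compounds 1 and 3, each carrying a bis(trifluoromethyl)phenyl on the urea nitrogen, sit far below compound 2, which shows that the urea-attached ring can move the readout strongly, but no measured pair isolates a fluorine-for-methyl swap on that ring. Compound 4 is therefore expected to fall at 1.5 degrees C, somewhere between -1.5 degrees C and 4.5 degrees C, meaning an estimated step of a number 2.6 degrees C lower from compound 2 to compound 4 (beyond the scatter).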

Compound 4, shift of the target's melting temperature: 2.5 degrees C
Compound 4: the middle estimate sits 1.0 degrees C below what was measured, within the range that was stated.
By their numbers in this assay, from the lowest: compounds 1 and 3 (each within the scatter of the next); then compound 4; then compound 2.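

Swapping 5-fluoro-2-methylphenyl for 3,5-difluorophenyl on the urea nitrogen gives a clean reading of this position in this assay, with a step of a number 1.6 degrees C lower from compound 2 to compound 4 (beyond the scatter). The ring without a methyl group keeps a positive shift: compound 4 gives 2.5 degrees C, while compound 1, with its bis(trifluoromethyl)phenyl ring, gives -0.5 degrees C. No measurement here explains the step. As far as these compounds go, the swap removes the methyl and adds a fluorine together, and which of the two matters remains open. Also open, from the compounds shown here alone, is how a chlorine, a methoxy group or an amine on this ring would read.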